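Solubility across a shared core: from compound 2 to compound 3

The source may hold more compounds than are shown below. What is called first, only, known or untested is meant among the compounds shown, and "the series" means these compounds.

Measured so far:
compound 1, `COC(=O)C1=C(C)NC(c2nccs2)=NC1(C)c1ccc(S(C)(=O)=O)cc1`: 365 ug/mL
compound 2, `COC(=O)C1=C(CN2CC3CC2CO3)NC(c2nccs2)=NC1(C)c1ccc(F)cc1`: 564 ug/mL

Of the compounds shown here, two sharing a core have been measured in a physicochemical assay for solubility, read by HPLC, in phosphate buffer, at pH 6.5; a higher number here means a more soluble compound, a lower number a less soluble compound. In this assay compound 1 gives 365 ug/mL. Compound 2, built on the same core, gives 564 ug/mL in this assay. Compound 2 holds the higher of the two numbers, but its gap to compound 1 is within the scatter, so the two values cannot be ranked against each other.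

Compound 3, `COC(=O)C1=C(CN(C)C2(C(=O)O)CC2)NC(c2nccs2)=NC1(C)c1ccc(F)cc1`, is not yet measured. It differs from compound 2 in one place: a group of 8 heavy atoms (5 carbon, 1 nitrogen, 2 oxygen; one three-membered non-aromatic ring of carbon only) in place of a group of 7 heavy atoms (5 carbon, 1 nitrogen, 1 oxygen; 2 five-membered non-aromatic rings with 1 hetero atom each), on a saturated chain carbon bound to a double-bonded ring carbon. Within the data shown here, no step between measured compounds covers this kind of exchange, so there is nothing in the measured pair from which to read its size. The expectation here is an upward move, estimated at a 1.8-fold higher number from compound 2 to compound 3 (0.25 log units; within the scatter), beyond the scatter rather than within it. Compound 3 is accordingly expected to give about 1000 ug/mL in this assay, within a range from 450 ug/mL to 2200 ug/mL.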

Compound 3, solubility: > 510 ug/mL
Compound 3: a limit, no number; the forecaster's own chance of this, stated with the estimate: 25%; the middle value does not contradict the limit.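

For compound 3, this assay gives a limit and not a number, so no step can be read between compound 2 and compound 3: the limit of > 510 ug/mL in this assay, at which 1 of the 3 values shown sits.

The compounds shown leave open how the solubility of compound 3 actually compares with that of compound 2, and whether any gap between them lies beyond the scatter.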